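Benzyl on the Ring Nitrogen of a Weak Lipase Inhibitor

The source may hold more compounds than are shown below. What is called first, only, known or untested is meant among the compounds shown, and "the series" means these compounds.

Two compounds share a core and a trans-disubstituted cyclohexyl amide. Compound 1 `Nc1c(C(=O)N[C@H]2CC[C@@H](c3ccccc3)CC2)[nH]c(=O)[nH]c1=O` carries an amino group on that core, and in an assay on isolated protein for inhibition of endothelial lipase (Homo sapiens), read by LC-MS, with a stated time of 2 h, in the presence of a further agent that is not named here (on this read-out lower numbers stand for stronger inhibition and higher numbers for weaker inhibition), compound 1 gives "not determined" (no result reported), so no result is reported for it. Compound 2 `O=C(N[C@H]1CC[C@@H](c2ccccc2)CC1)c1[nH]c(=O)[nH]c(=O)c1O` carries a hydroxy group instead, and in this assay compound 2 gives 25000 nM, the only number shown in this set and a weak one. Compound 3 `O=C(N[C@H]1CC[C@@H](c2ccccc2)CC1)c1[nH]c(=O)n(Cc2ccccc2)c(=O)c1O` differs from compound 2 by a single change: benzyl in place of hydrogen on an aromatic nitrogen. Among the compounds with values here, no measured pair in this set shows what such a change does in this assay, so the direction of the step rests on expectation alone. Compound 3 is expected to gain somewhat, with a step of a 3.1-fold lower number from compound 2 to compound 3 (0.49 log units; beyond the scatter) estimated to exceed the usual scatter. Compound 3 is therefore estimated at 8000 nM in this assay, within a range from 2000 nM to 40000 nM.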

Compound 3, half-maximal inhibitory concentration: 32000 nM
For compound 3 the middle estimate is 4.0-fold (0.60 log units) below the measured one; low and high end bracket the measured number.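

Benzyl in place of hydrogen on the aromatic nitrogen gives, in this assay, a 1.3-fold higher number from compound 2 to compound 3 (0.11 log units; within the scatter), so compound 2 and compound 3 cannot be told apart on this read-out. Within the data shown here, this is the first reading at this position, and it shows that the hydrogen on this ring nitrogen can give way to a group of 7 heavy atoms, including a six-membered aromatic ring, with no step beyond the scatter. Nothing measured here bears on why the number stays in the same range.

Going by these compounds, whether a methyl group, a longer chain such as phenethyl, or a benzyl carrying a carboxylic acid on its ring would read the same at this nitrogen remains open. Compound 1 has no reported result, and the exchange of hydroxy for amino on the shared core stays unread.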